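Swapping an aryl ring for cycloheptyl on the piperazine nitrogen

The source may report more compounds than this note shows. Statements on the series, on what has been measured and on what is new or still open speak of the compounds shown alone.

Measured compounds:
compound 1 `Nc1scc(CN2CCN(c3cccc(C(F)(F)F)c3)CC2)c1C(=O)c1ccc(Cl)cc1`, -80%
compound 2 `Nc1scc(CN2CCN(c3ccc(OC(F)(F)F)cc3)CC2)c1C(=O)c1ccc(Cl)cc1`, -74%

In a functional assay on CHO cells with adenosine receptor A1 (Homo sapiens) as the target, read by cAMP accumulation and immunoassay, with a stated time of 6 min, tested at 10 uM (a lower number here means a stronger effect, a higher number a weaker effect of the compound at the concentration tested), compound 1 gives -80%. Within the data shown here, compound 2 gives -74% in this assay; it stands highest of the two numbers, but the single measured step, a number 6 percentage points higher from compound 1 to compound 2 (within the scatter), lies within the scatter, so the two compounds cannot be told apart.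

Compound 3 `Nc1scc(CN2CCN(C3CCCCCC3)CC2)c1C(=O)c1ccc(Cl)cc1` has not been measured. It differs from compound 2 in this way: cycloheptyl in place of 4-(trifluoromethoxy)phenyl on an amine nitrogen in a ring. Among the measured compounds shown here, no measured step bears on this change: the one known step only exchanges one aromatic ring for another, whereas here a non-aromatic ring enters. The expectation therefore rests on the two values alone, and the step of a number 14 percentage points higher from compound 2 to compound 3 (beyond the scatter) is estimated with wide uncertainty. Compound 3 is expected to give about -60% in this assay, within a range from -95% to -15%.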

Compound 3, a percentage reported as activity, at one concentration (the size of the read-out at that concentration, not a potency): -25%
For compound 3 the middle estimate is 35 percentage points below the measured one, and the stated range covers the measured number.
By their numbers in this assay, from the lowest: compounds 1 and 2 (each within the scatter of the next); then compound 3.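

In this assay the two aromatic rings of compounds 1 and 2 give values within the scatter of each other, but cycloheptyl brings a number 49 percentage points higher from compound 2 to compound 3 (beyond the scatter) and a number 55 percentage points higher from compound 1 to compound 3 (beyond the scatter) and so leaves compound 3 with the weakest effect of the three. Among these compounds, the earlier pair showed only that one substituted phenyl ring can replace another on this piperazine nitrogen without a readable change, whereas these large steps show that the read-out does depend on the group placed here. Nothing available explains why the number rises so far.

These three compounds cannot separate the loss of the aromatic ring from the arrival of a seven-membered ring or from the loss of the fluorine atoms. Cyclohexyl or an unsubstituted phenyl ring on the same nitrogen could begin to tell these changes apart.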